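From methoxycarbonyl to hydroxymethyl on compound 1

The source may report more compounds than this note shows. Statements on the series, on what has been measured and on what is new or still open speak of the compounds shown alone.

In a functional assay on A549 cells (Homo sapiens) for cytotoxicity, read by MTT assay, with a stated time of 72 h (a higher number here means that more compound is needed for the effect, a lower number that less compound is needed), compound 1 (`CCc1cccc2c(OC)c(-c3occ(C)c3C(=O)OC)ccc12`) gives 1.5 ug/mL, the lowest number of the three measured, though not clearly apart from all of them. Compound 3 (`CCOc1c(-c2occ(C)c2C(=O)OC)ccc2c(CC)cccc12`) gives 2.4 ug/mL, and the comparison shows a 1.6-fold higher number from compound 1 to compound 3 (0.20 log units; within the scatter). That change lies away from the group at issue here and says little about it. Compound 2 (`CCc1cccc2c(OC)c(-c3occ(C)c3C(=S)OC)ccc12`) gives 6.2 ug/mL. Compound 4 (`CCc1cccc2c(OC)c(-c3occ(C)c3CO)ccc12`) carries hydroxymethyl in place of methoxycarbonyl on an aromatic carbon. Among the measured compounds shown here, the only measured change to this same group gave a 4.1-fold higher number from compound 1 to compound 2 (0.62 log units; beyond the scatter), and no measured compound has hydroxymethyl there. A modest rise of similar size is therefore expected, an estimated 3.0-fold higher number from compound 1 to compound 4 (0.48 log units; beyond the scatter). For compound 4, the expected value is 4.5 ug/mL, with an estimated range of 1.5 ug/mL to 15 ug/mL.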

Compound 4, concentration for half-maximal effect: 9.6 ug/mL
Compound 4: middle estimate off by 2.1-fold (0.33 log units), on the low side; the range from low to high includes it.
By their numbers in this assay, from the lowest: compounds 1 and 3 (each within the scatter of the next); then compounds 2 and 4 (each within the scatter of the next).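

In this assay, hydroxymethyl in place of methoxycarbonyl on compound 1 raises the number beyond the scatter (a 6.4-fold higher number from compound 1 to compound 4 (0.81 log units; beyond the scatter)), so both replacements shown at this aromatic carbon raise it. The sulfur-bearing group of compound 2 and the smaller hydroxymethyl of compound 4 are not told apart (a 1.5-fold higher number from compound 2 to compound 4 (0.19 log units; within the scatter)). Nothing measured here explains these steps. The compounds shown leave open how a carboxylic acid or an aminomethyl group would read at this carbon. They also leave open whether hydroxymethyl would give a similar step on compound 3.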